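A few compounds are considered here, and "the series" means these few. Any claim that something is new, unique, unknown or untested is made for them only; others in the source may bear on it.

Measured compounds in a functional assay on HeLa cells (Homo sapiens) for antiproliferative activity, read by CCK-8 assay, with a stated time of 72 h, tested at 2 uM; a lower number here means a weaker effect, a higher number a stronger effect of the compound at the concentration tested:
compound 1 `Nc1ccccc1NC(=O)c1ccc(CSC(=S)N2CCN(Cc3ccccn3)CC2)cc1` gives 14.2%
compound 2 `Nc1ccccc1NC(=O)c1ccc(CSC(=S)N2CCN(C(c3ccccc3)c3ccccc3)CC2)cc1` gives 8%
compound 3 `Nc1ccccc1NC(=O)c1ccc(CSC(=S)N2CCc3ccccc32)cc1` gives 38%

Compound 3 stands highest of the three numbers. Its nearest neighbour is compound 1, whose number is lower by a margin beyond the usual scatter, and the furthest is compound 2, lower still and also beyond the scatter. Going by the values given here, no pairwise steps among the measured compounds are given, so only the values themselves can be compared.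

Compound 4 `Nc1ccccc1NC(=O)c1ccc(CSC(=S)N2CCCc3ccccc32)cc1` is not yet measured. It differs from compound 3 in one place: 1,2,3,4-tetrahydroquinolin-1-yl in place of 2,3-dihydro-1H-indol-1-yl on a thiocarbonyl carbon. The five-membered non-aromatic ring with one hetero atom becomes a six-membered non-aromatic ring with one hetero atom; the aromatic ring of carbon only stays, and donors, acceptors and charge are unchanged.

Among the compounds with values here, with no measured step of this kind to lean on, the author expects in this assay no step beyond the scatter, in either direction, as the estimated step of a number 3 percentage points lower from compound 3 to compound 4 (within the scatter). For compound 4 the estimate is 35%, within a range from 15% to 58%.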

Compound 4, a percentage reported as inhibition, at one concentration (the size of the read-out at that concentration, not a potency): 26.1%
Compound 4: middle estimate off by 8.9 percentage points, on the high side; low and high end bracket the measured number.
By their numbers in this assay, from the lowest: compounds 2 and 1 (each within the scatter of the next); then compound 4; then compound 3.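

In this assay, going by these compounds alone, the change on a thiocarbonyl carbon, 1,2,3,4-tetrahydroquinolin-1-yl in place of 2,3-dihydro-1H-indol-1-yl, gives a number 11.9 percentage points lower from compound 3 to compound 4 (beyond the scatter) and is the first single-place comparison. It shows that this position responds to the non-aromatic ring alone: going from a five-membered to a six-membered ring moves the number beyond the scatter, while the aromatic ring of carbon only, the donors, the acceptors and the charge all stay the same. No independent measurement bears on why the number moves.

One step cannot show whether a seven-membered non-aromatic ring would continue the direction, or how a methoxy group or a fluorine on the aromatic ring would act. As far as these compounds go, since the read-out comes from a single concentration, the potency of compound 3 and compound 4 also remains open.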